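A Double-Bond Geometry Change in a Diacid Chain

The source may report more compounds than this note shows. Statements on the series, on what has been measured and on what is new or still open speak of the compounds shown alone.

Measured so far in a physicochemical assay for lipophilicity; on this read-out lower numbers stand for lower lipophilicity and higher numbers for higher lipophilicity:
compound 1, `C=C1C(=O)O[C@@H]2[C@H]3C[C@@]4(C)C=CC3(CC43C(=O)O[C@@H]4C5C(C)=CC(=O)C5=C(C)C[C@H](CC(=O)CC(C)C)C43)[C@](C)(O)CC[C@@H]12`: 1.8
compound 2, `CC(C)=CCC/C(C)=C/CC/C(C)=C/CC/C(=C\C(=O)O)C(=O)O`: 1.3

Two compounds have numbers in this assay. Compound 1 is a large polycyclic lactone, and in this assay compound 1 gives 1.8. Compound 2 is an open-chain diacid, and in this assay compound 2 gives 1.3. Compound 2 stands as the lower of the two numbers; the number for compound 1 lies higher, and that gap is beyond the scatter of this assay.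

The account now turns from compound 2 to compound 3, `CC(C)=CCC/C(C)=C/CC/C(C)=C/CC/C(=C/C(=O)O)C(=O)O`, which has not yet been measured in this assay. The difference between them is small on paper: the two compounds have the same atoms and bonds and differ only in configuration as drawn: 1 of 3 stereo elements differ; a double bond is drawn E in compound 2 and Z in compound 3. Nothing leaves and nothing enters.

For the measured compounds named here, with no step between two measured compounds available for comparison, the expectation rests on the unchanged atom count alone. The step expected from compound 2 to compound 3 in this assay is no change at the digits printed from compound 2 to compound 3 (within the scatter), none beyond the scatter in either direction. For compound 3 the estimated value in this assay is 1.3, expected to fall between 0.9 and 1.7.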

Compound 3, partition coefficient: 1.4
Beside the measured number, compound 3's estimate is 0.10 log units below it; the measured number falls inside the stated range.
By their numbers in this assay, from the lowest: compounds 2 and 3 (each within the scatter of the next); then compound 1.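

For the compounds shown here, until this point no two measured compounds differed in one place only, so this is the first step that can be read in this assay: a double bond drawn E on one side and Z on the other comes with a number 0.10 log units higher from compound 2 to compound 3 (within the scatter). In this open-chain diacid, then, the read-out does not separate the two drawn forms of this double bond, and configuration at this position makes no difference that can be told from the usual spread of repeated measurements. The comparison is a clean one, as no other part of the structure enters into it: the fact that compounds 2 and 3 differ only in the configuration as drawn.

What the compounds shown leave open is whether the two forms would stay as close if the carboxylic acid groups were replaced by methyl esters or by primary amides, or if only one carboxylic acid remained on the chain. They also leave open whether the same holds for a shorter chain, with fewer of the repeating units that carry the methyl groups, since a single pair of forms on one chain speaks for that chain alone.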